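The compounds below may be only part of what the source reports. "The series", "measured", "known", "first", "only" and "open" are said of these compounds alone.

Compound 1 `C/C(=N\N(C)S(=O)(=O)c1cc([N+](=O)[O-])ccc1C)c1cnn2ccc(C#N)cc12`: 600 nM
Compound 2 `CCC/C(=N\N(C)S(=O)(=O)c1cc([N+](=O)[O-])ccc1C)c1cnn2ccc(C#N)cc12`: > 1000 nM

In an assay on isolated protein for inhibition of phosphatidylinositol 4,5-bisphosphate 3-kinase catalytic subunit beta isoform (Homo sapiens), read by 33P incorporation, with a stated time of 60 min (on this read-out lower numbers stand for stronger inhibition and higher numbers for weaker inhibition), compound 1 gives 600 nM, the only plain number shown. Compound 2 reaches only the assay limit of > 1000 nM, so no number is known for it; that is the limit of > 1000 nM in this assay, at which 1 of the 2 values shown sits. For the measured compounds named here, the single measured step, an at least 1.6-fold higher number from compound 1 to compound 2 (0.22 log units; that floor lies within the scatter), has a floor within the scatter. Compound 3 `C/C(=N\N(C)S(=O)(=O)c1cc([N+](=O)[O-])ccc1C)c1cnn2ccc(Br)cc12` differs from compound 1 in one place: bromo in place of cyano on an aromatic carbon. Going by the values given here, no measured step touches this position, so the data give no direction. The expected number for compound 3 is 800 nM, with a range from 250 nM to 2500 nM. The step of a 1.3-fold higher number from compound 1 to compound 3 (0.12 log units; within the scatter) is thus expected to stay within the scatter.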

Compound 3, half-maximal inhibitory concentration: > 1000 nM
Compound 3: a limit, no number (the forecaster's own chance of this, stated with the estimate: 35%); at least 1.2-fold (0.09 log units) between middle value and limit.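

For the compounds shown here, replacing the nitrile with bromo on this aromatic carbon gives the first reading at this position: in this assay compound 3 reaches only a limit, > 1000 nM, and no number is known for it. The step, an at least 1.6-fold higher number from compound 1 to compound 3 (0.22 log units; that floor lies within the scatter), has a floor within the scatter, so a real loss from this change is not established. Only compound 1 keeps a plain number, while the other compounds share one limit: the limit of > 1000 nM in this assay, at which 2 of the 3 values shown sit.

From the compounds shown here alone, the true size of the change therefore stays open. So does the effect of a chloro or an amine on this carbon, and whether any group there would give a lower number than compound 1.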